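Flipping the double bond in the chloro analogue

A few compounds are considered here, and "the series" means these few. Any claim that something is new, unique, unknown or untested is made for them only; others in the source may bear on it.

Measured compounds:
compound 1, `O=S(=O)(/C=C/c1ncccc1F)c1ccccc1F`, 176 nM
compound 2, `O=S(=O)(/C=C\c1ncccc1F)c1ccccc1F`, 482 nM
compound 3, `O=S(=O)(/C=C/c1ncccc1Cl)c1ccccc1F`, 30 nM

In an assay on U2OS cells for activation of nuclear factor erythroid 2-related factor 2 (Homo sapiens), read by beta-arrestin recruitment, with a stated time of 6 h (on this read-out higher numbers stand for an effect only at larger amounts of compound and lower numbers for an effect already at smaller amounts), compound 1 gives 176 nM, compound 2 gives 482 nM and compound 3 gives 30 nM. Compound 3 stands lowest of the three numbers, set apart from its nearest neighbour by a 5.9-fold lower number from compound 1 to compound 3 (0.77 log units; beyond the scatter), and further still from compound 2, whose number is the highest of the three.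

Compound 4, `O=S(=O)(/C=C\c1ncccc1Cl)c1ccccc1F`, has not yet been measured. the two compounds have the same atoms and bonds and differ only in configuration as drawn: 1 of 1 stereo elements differ; a double bond is drawn E in compound 3 and Z in compound 4

Going by the values given here, one measured step bears on this change: a 2.7-fold higher number from compound 1 to compound 2 (0.44 log units; beyond the scatter), a step that rests on (the fact that compounds 1 and 2 differ only in the configuration as drawn). That step was modest but beyond the scatter, and it points in one direction only. Carried over to the chloro pair, compound 4 is therefore expected to show a 2.7-fold higher number from compound 3 to compound 4 (0.43 log units; beyond the scatter). On that basis compound 4 is estimated at 80 nM, with a range from 35 nM to 200 nM.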

Compound 4, half-maximal effective concentration: 1030 nM
The estimate for compound 4 lay 13-fold (1.11 log units) below the measured number; measured number outside the range, above it.
By their numbers in this assay, from the lowest: compound 3; then compound 1; then compound 2; then compound 4.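

With chloro in place of fluoro, turning the double bond from E to Z gives a 34-fold higher number from compound 3 to compound 4 (1.54 log units; beyond the scatter) in this assay, a large step where the fluoro pair gave only a 2.7-fold higher number from compound 1 to compound 2 (0.44 log units; beyond the scatter), so the cost of the Z form is not the same in the two pairs. The halogen change also differs with configuration, lowering the number in the E pair while giving a 2.1-fold higher number from compound 2 to compound 4 (0.33 log units; beyond the scatter) in the Z pair, so it does not carry over from one form to the other: the same change on two cores in this assay, a 5.9-fold lower number (0.77 log units; beyond the scatter) from compound 1 to compound 3 and a 2.1-fold higher number (0.33 log units; beyond the scatter) from compound 2 to compound 4, 13-fold (1.10 log units) apart, beyond the scatter of two such steps. In both pairs the E compound gives the lower number, and the chloro pair differs in configuration alone: the fact that compounds 3 and 4 differ only in the configuration as drawn.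

The compounds shown leave open whether a bromo or a methyl group in place of the chloro would keep this preference for the E form, or widen or narrow the gap between the two forms.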